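A few compounds are considered here, and "the series" means these few. Any claim that something is new, unique, unknown or untested is made for them only; others in the source may bear on it.

Three compounds were tested in a functional assay on A-431 cells (Homo sapiens) for cytotoxicity, read by MTT assay, with a stated time of 72 h, tested at 100 uM (on this read-out lower numbers stand for less inhibition of growth and higher numbers for more inhibition of growth at the one concentration tested), and a fourth awaits its number. Compound 1 `Cc1ccnc(/C(N)=N/NC(=S)N2CCOCC2)c1` gives 82.8% in this assay. Compound 2 `Cc1cccc(/C(N)=N/NC(=S)N2CCSCC2)n1` gives 80.7%, and compound 3 `Cc1ccnc(/C(N)=N/NC(=S)N2CCSCC2)c1` gives 79.6%. All three numbers lie within the usual scatter of one another, so no order among them can be read.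

Compound 1 and compound 3 differ by one change, (morpholin-4-yl in place of thiomorpholin-4-yl on a thiocarbonyl carbon), and the step of a number 3.2 percentage points higher from compound 3 to compound 1 (within the scatter) is within the scatter. Compound 2 and compound 3 share the same atoms joined differently; the difference between the two cores is not broken down here.

Compound 4 `Cc1cccc(/C(N)=N/NC(=S)N2CCOCC2)n1` is not yet measured. For the measured compounds named here, it differs from compound 2 by morpholin-4-yl in place of thiomorpholin-4-yl on a thiocarbonyl carbon, which is the same change as the one from compound 3 to compound 1, made at the same place. The expected step here, a number 2.3 percentage points higher from compound 2 to compound 4 (within the scatter), rests on the earlier step of a number 3.2 percentage points higher from compound 3 to compound 1 (within the scatter), which stayed within the scatter. Compound 4 is therefore estimated at 83%, with a range from 73% to 91%.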

Compound 4, percent growth inhibition at one concentration: 84.8%
Beside the measured number, compound 4's estimate is 1.8 percentage points below it; measured number inside the range.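

In this assay, morpholin-4-yl in place of thiomorpholin-4-yl on a thiocarbonyl carbon gives a number 4.1 percentage points higher from compound 2 to compound 4 (within the scatter) on the second core. Set beside the earlier reading of the same change, the two steps do not differ: the same change on two cores in this assay, a number 3.2 percentage points higher (within the scatter) from compound 3 to compound 1 and a number 4.1 percentage points higher (within the scatter) from compound 2 to compound 4, 0.9 percentage points apart, within the scatter of two such steps. This shows that the change behaves alike on these two cores, in that neither step rises beyond the scatter, but it does not show that morpholin-4-yl gives more inhibition of growth than thiomorpholin-4-yl on either core, and two cores say nothing about any others.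

The compounds shown leave open whether a group such as piperidin-1-yl, dimethylamino or a piperazine ring carrying a methyl group on the same thiocarbonyl carbon would give a step beyond the scatter. They also leave open whether the morpholin-4-yl and thiomorpholin-4-yl compounds would separate at lower concentrations or on other cell lines.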